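Phenyl substituent changes on the semicarbazone arm

The source may hold more compounds than are shown below. What is called first, only, known or untested is meant among the compounds shown, and "the series" means these compounds.

Compound 1 `CN(C)CCn1cnnc1-c1cc(Oc2ccc(NC(=O)N/N=C/c3ccc(Cl)cc3Cl)cc2F)ccn1`: 130 nM
Compound 2 `COc1ccc(/C=N/NC(=O)Nc2ccc(Oc3ccnc(-c4nncn4CCN(C)C)c3)c(F)c2)c(OC)c1OC`: 1790 nM
Compound 3 `CN(C)CCn1cnnc1-c1cc(Oc2ccc(NC(=O)N/N=C/c3ccc(F)cc3)cc2F)ccn1`: 1980 nM

In a functional assay on NCI-H460 cells (Homo sapiens) for cytotoxicity, read by MTT assay, with a stated time of 72 h (a higher number here means a weaker inhibitor, a lower number a stronger inhibitor), compound 3 gives the highest of the three numbers, its nearest neighbour being compound 2 and its furthest compound 1. The step to compound 4 `CN(C)CCn1cnnc1-c1cc(Oc2ccc(NC(=O)N/N=C/c3ccc(O)c(O)c3)cc2F)ccn1` is 3,4-dihydroxyphenyl in place of 4-fluorophenyl on a carbon with a double bond to nitrogen. Among the compounds with values here, no measured step exchanges a halogen for hydroxyl groups at this position, so the bearing of the earlier steps is indirect. They show that this aryl group matters: a 14-fold higher number from compound 1 to compound 2 (1.14 log units; beyond the scatter) and a 15-fold higher number from compound 1 to compound 3 (1.18 log units; beyond the scatter) were both large, whereas a 1.1-fold higher number from compound 2 to compound 3 (0.04 log units; within the scatter) lay within the scatter, so two quite different replacements of the dichlorophenyl landed at nearly the same weak level. Compound 4 is therefore expected to stay close to compound 3, with an expected 1.3-fold higher number from compound 3 to compound 4 (0.10 log units; within the scatter) in this assay, and a wide range allowing either direction. For compound 4 the estimate in this assay is 2500 nM, between 800 nM and 8000 nM.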

Compound 4, half-maximal inhibitory concentration: 1930 nM
The estimate for compound 4 lay 1.3-fold (0.11 log units) above the measured number; measured number inside the range.
By their numbers in this assay, from the lowest: compound 1; then compounds 2, 4 and 3 (each within the scatter of the next).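

In this assay, exchanging 4-fluorophenyl for 3,4-dihydroxyphenyl gives a 1.0-fold lower number from compound 3 to compound 4 (0.01 log units; within the scatter) even though the entering group has 2 hydrogen-bond donors and the leaving group has none. Exchanging 2,3,4-trimethoxyphenyl for 3,4-dihydroxyphenyl gives a 1.1-fold higher number from compound 2 to compound 4 (0.03 log units; within the scatter) as well, so three unlike aryl groups now stand within the scatter of one another on the carbon with a double bond to nitrogen. Within the data shown here, only 2,4-dichlorophenyl stands apart from this group, and the new comparison with it shows a 15-fold higher number from compound 1 to compound 4 (1.17 log units; beyond the scatter) in the same large range as the earlier steps.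

On these data alone, whether a single chlorine, an amine or a carboxylic acid on the phenyl would fall with compound 1 or with the other three remains open. The cause of the gap between 2,4-dichlorophenyl and the other aryl groups also remains open, with no supporting measurement available here.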